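Trading a Methyl on Oxygen for Hydrogen

The source may report more compounds than this note shows. Statements on the series, on what has been measured and on what is new or still open speak of the compounds shown alone.

Measured compounds and their values:
- Compound 1, `COc1cc(C)cc(-c2nn(CC#N)cc2-c2ccc(-c3cccc(C(C)=O)c3)nc2)c1`: 4290 nM
- Compound 2, `Cc1cc(O)cc(-c2nn(CC#N)cc2-c2ccnc(-c3ccc(Oc4ccccc4)cc3)c2)c1`: 3220 nM
- Compound 3, `COc1cc(C)cc(-c2nn(CC#N)cc2-c2ccnc(-c3ccc(N(C)C)cc3)c2)c1`: 968 nM

Of the compounds shown here, three sharing one core have been tested in a functional assay on NCI-H226 cells (Homo sapiens) for inhibition, read by sulforhodamine B assay, with a stated time of 48 h; a higher number here means a weaker inhibitor of growth, a lower number a stronger inhibitor of growth. Compound 3 `COc1cc(C)cc(-c2nn(CC#N)cc2-c2ccnc(-c3ccc(N(C)C)cc3)c2)c1` gives 968 nM, the lowest of the three numbers. Compound 2 `Cc1cc(O)cc(-c2nn(CC#N)cc2-c2ccnc(-c3ccc(Oc4ccccc4)cc3)c2)c1` gives 3220 nM, and compound 1 `COc1cc(C)cc(-c2nn(CC#N)cc2-c2ccc(-c3cccc(C(C)=O)c3)nc2)c1` gives 4290 nM; both stand beyond the scatter above compound 3, so compound 3 is the strongest inhibitor of growth among these three. Compound 2 and compound 3 differ in two places at once, so their gap cannot be assigned to either change alone.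

The next compound, compound 4 `Cc1cc(O)cc(-c2nn(CC#N)cc2-c2ccnc(-c3ccc(N(C)C)cc3)c2)c1`, changes compound 3 in a single spot: hydrogen in place of methyl on an oxygen on an aromatic ring, turning the 3-methoxy-5-methylphenyl group into 3-hydroxy-5-methylphenyl. For the measured compounds named here, no measured pair shows this change in isolation, so its effect is unknown. The expectation is a small step in this assay, if any, in the weaker direction, since compound 2, the other hydroxy-bearing compound, gives 3220 nM. Compound 4 is estimated at 1500 nM, in the range 500 nM to 5000 nM. That estimate corresponds to an expected step of a 1.5-fold higher number from compound 3 to compound 4 (0.19 log units; within the scatter).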

Compound 4, concentration for 50% growth inhibition: 4180 nM
The estimate for compound 4 lay 2.8-fold (0.45 log units) below the measured number; measured number inside the range.
By their numbers in this assay, from the lowest: compound 3; then compounds 2, 4 and 1 (each within the scatter of the next).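

In this assay, the methoxy to hydroxy change can now be read on its own with the dimethylamino group held constant, and it gives a 4.3-fold higher number from compound 3 to compound 4 (0.64 log units; beyond the scatter), which shows that the methyl on this oxygen matters for growth inhibition in this series. With the hydroxy group kept, dimethylamino in place of phenoxy gives a 1.3-fold higher number from compound 2 to compound 4 (0.11 log units; within the scatter), so these two groups cannot be told apart in this setting. No measurement shown here explains the effect of removing the methyl.

Going by these compounds, whether an ethoxy group or an amine at this position would give a number closer to that of compound 3 remains open. On these data alone, it is also open whether the methoxy to hydroxy change would give a step of similar size with phenoxy in place of dimethylamino.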